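The source may hold more compounds than are shown below. What is called first, only, known or untested is meant among the compounds shown, and "the series" means these compounds.

Measured compounds in a functional assay on the whole organism (blood, strain Wistar-Okamoto) with Rattus norvegicus as the target, with a stated time of 5 days; on this read-out higher numbers stand for an effect only at larger amounts of compound and lower numbers for an effect already at smaller amounts:
Compound 1 `CC(C)(C)C/N=C(\NC#N)Nc1ccncc1` gives 5 mg/kg.
Compound 2 `CCC(CC)/N=C(\NC#N)Nc1ccncc1` gives 2.5 mg/kg.
Compound 3 `CC(C)CC(C)/N=C(\NC#N)Nc1ccncc1` gives 35 mg/kg.

Compound 3 stands at the highest number of the three in this assay. The step of a 7.0-fold higher number from compound 1 to compound 3 (0.85 log units; beyond the scatter) and the step of a 14-fold higher number from compound 2 to compound 3 (1.15 log units; beyond the scatter) both lie beyond the scatter, while the step of a 2.0-fold lower number from compound 1 to compound 2 (0.30 log units; within the scatter) does not. For the measured compounds named here, the group on the double-bonded nitrogen therefore drives the only steps beyond the scatter seen so far.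

Compound 4 `CCC(C)C(C)/N=C(\NC#N)Nc1ccncc1` has not been measured. It differs from compound 3 by sec-butyl in place of isobutyl on a saturated chain carbon bound to a double-bonded nitrogen and a saturated chain carbon. Going by the values given here, no measured step repeats this exact change. The steps of a 7.0-fold higher number from compound 1 to compound 3 (0.85 log units; beyond the scatter) and a 14-fold higher number from compound 2 to compound 3 (1.15 log units; beyond the scatter) show that reshaping the group on the double-bonded nitrogen can shift this assay by a large amount in either direction, and compound 3 already holds the highest number, so a step toward a lower number is expected, though of uncertain size. For compound 4 the expected step is a 2.9-fold lower number from compound 3 to compound 4 (0.46 log units; beyond the scatter). Compound 4 is estimated at 12 mg/kg, with a range from 4 mg/kg to 35 mg/kg.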

Compound 4, minimum effective dose: 8 mg/kg
For compound 4 the middle estimate is 1.5-fold (0.18 log units) above the measured one; measured number inside the range.
By their numbers in this assay, from the lowest: compounds 2, 1 and 4 (each within the scatter of the next, the first and the last beyond it); then compound 3.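

In this assay, sec-butyl in place of isobutyl gives a clear change (a 4.4-fold lower number from compound 3 to compound 4 (0.64 log units; beyond the scatter)), so this position responds to how the same four carbons are joined, not only to how many there are. The 1,2-dimethylbutyl group still stands apart from pentan-3-yl (a 3.2-fold higher number from compound 2 to compound 4 (0.51 log units; beyond the scatter)), whereas its step from neopentyl stays within the scatter (a 1.6-fold higher number from compound 1 to compound 4 (0.20 log units; within the scatter)), so these two groups cannot be told apart on this read-out. Nothing at hand accounts for the difference between the two isomeric groups.

As far as these compounds go, all four compounds carry a branched alkyl group at this position, so it remains open how a straight hexyl chain or a cyclohexyl ring would behave there. From the compounds shown here alone, whether a hydroxyl or an amine on this chain would be tolerated also remains open.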